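The source may hold more compounds than are shown below. What is called first, only, known or untested is meant among the compounds shown, and "the series" means these compounds.

Measured so far:
Compound 1 `CN(C)CCN(CCN(C)C)c1cccc(C(=O)N2CCc3ccc(OS(N)(=O)=O)cc3C2)c1`: 0%
Compound 2 `CCN(Cc1ccccn1)c1ccc(C(=O)N2CCc3ccc(OS(N)(=O)=O)cc3C2)cc1`: 42.5%
Compound 3 `CC(C)CCN(CCC(C)C)c1ccc(C(=O)N2CCc3ccc(OS(N)(=O)=O)cc3C2)cc1`: 47%

In an assay on HEK293 cells for inhibition of Steryl-sulfatase (Homo sapiens), tested at 0.1 uM (a higher number here means a stronger effect of the compound at the concentration tested, a lower number a weaker effect), compound 1 gives the lowest of the three numbers; compound 2 stands higher beyond the scatter, and compound 3 higher still. Compound 4 `CCCN(Cc1ccccc1)c1cccc(C(=O)N2CCc3ccc(OS(N)(=O)=O)cc3C2)c1` has not yet been measured. It differs from compound 1 in one place: benzyl(propyl)amino in place of bis(2-(dimethylamino)ethyl)amino on an aromatic carbon. Among the measured compounds shown here, the only measured step, a number 4.5 percentage points higher from compound 2 to compound 3 (within the scatter), exchanges one amino group for another at a different place and stays within the scatter, so it does not directly bear on this change. What remains is that compound 1 sits far below the two compounds carrying other amino groups. An upward step is therefore expected, a number 30 percentage points higher from compound 1 to compound 4 (beyond the scatter). Compound 4 is estimated at 30%, with a range from 5% to 55%.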

Compound 4, a percentage reported as inhibition, at one concentration (the size of the read-out at that concentration, not a potency): 23.1%
Compound 4: the middle estimate sits 6.9 percentage points above what was measured; the measured number falls inside the stated range.
By their numbers in this assay, from the lowest: compound 1; then compound 4; then compounds 2 and 3 (each within the scatter of the next).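

Changing the amino group at this position does change the read-out: on an aromatic carbon meta to a large group, benzyl(propyl)amino in place of bis(2-(dimethylamino)ethyl)amino gives a number 23.1 percentage points higher from compound 1 to compound 4 (beyond the scatter) in this assay. The two groups have the same number of heavy atoms, so that count does not separate them; the entering group instead brings an aromatic ring and fewer nitrogens. No measured evidence accounts for the rise. On these data alone, whether the ring or the loss of nitrogens matters remains open, and dipropylamino, which has no ring and a single nitrogen, would help separate the two.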